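Ethynyl in place of furan-2-yl: working notes

The source may report more compounds than this note shows. Statements on the series, on what has been measured and on what is new or still open speak of the compounds shown alone.

Of the compounds shown here, two have numbers so far. In an ADME assay on MRC5 cells (Homo sapiens), read by MTT assay, with a stated time of 72 h (a higher number here means a weaker inhibitor, a lower number a stronger inhibitor), compound 1 `COc1ncnc2c1c(-c1cc3ccccc3o1)cn2[C@@H]1O[C@H](CO)[C@@H](O)[C@H]1O` gives 65600 nM and compound 2 `COc1nc(N)nc2c1c(-c1ccco1)cn2[C@@H]1O[C@H](CO)[C@@H](O)[C@H]1O` gives 89700 nM. These two values lie within the scatter of each other, so compound 2 stands level with compound 1 on the available numbers, and neither value marks out a stronger inhibitor.

The next compound to be read is compound 3 `C#Cc1cn([C@@H]2O[C@H](CO)[C@@H](O)[C@H]2O)c2nc(N)nc(OC)c12`. It carries ethynyl in place of furan-2-yl on an aromatic carbon of the five-membered aromatic ring with 1 nitrogen (ethynyl in place of furan-2-yl on an aromatic carbon). The rest of compound 2 stays as it is.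

Among the compounds with values here, no measured compound carries ethynyl, and no measured pair isolates a change at this place, so the data offer no direct guide to the size of this step. The expected step in this assay, a 2.6-fold lower number from compound 2 to compound 3 (0.41 log units; beyond the scatter), is a moderate one towards a lower number, though one that stays within the scatter remains possible. For compound 3 the estimated value is 35000 nM, with an expected range of 6000 nM to 95000 nM.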

Compound 3, half-maximal inhibitory concentration: > 100000 nM
Compound 3: only a limit was reported (the forecaster's own chance of this, stated with the estimate: 30%); middle value at least 2.8-fold (0.45 log units) away from the limit.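

In this assay, compound 3 gives > 100000 nM, which is a limit of the assay and not a number. Within the data shown here, replacing furan-2-yl with ethynyl on this aromatic carbon gives an at least 1.1-fold higher number from compound 2 to compound 3 (0.04 log units; that floor lies within the scatter), the first reading of a change at this place, and it shows no sign of a lower number with ethynyl in this assay. This reading fixes only one side of the step, so its true size stays unknown and it cannot be said to pass beyond the scatter, with compound 3 resting on the ceiling of the assay: the limit of > 100000 nM in this assay, at which 1 of the 3 values shown sits.

Compound 1 and compound 2 differ in more than one place, so they add nothing about this position, and whether compound 3 truly stands apart from compound 2 remains unsettled. Also open, going by these compounds, is how this aromatic carbon responds to other kinds of group, such as an amine, a carboxylic acid or a longer chain, and a reading of any of these would count only if its value fell clear of the limit in this assay.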